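The source may hold more compounds than are shown below. What is called first, only, known or untested is meant among the compounds shown, and "the series" means these compounds.

Three measured compounds share one core and differ only in a small alkyl group and in how that core is arranged. Compound 1 `CCc1c(C(=O)N[C@@H](C)c2ccc(C(=O)O)cc2)nnn1Cc1ccc(C(F)(F)F)cc1` carries an ethyl group. In a functional assay on CHO cells for antagonist activity at prostaglandin E2 receptor EP4 subtype (Homo sapiens), read by calcium flux, with a stated time of 15 min (a higher number here means a weaker inhibitor, a lower number a stronger inhibitor), compound 1 gives > 10000 nM, which is a limit of the assay and not a number. Compound 2 `CCCc1c(C(=O)N[C@@H](C)c2ccc(C(=O)O)cc2)nnn1Cc1ccc(C(F)(F)F)cc1` differs from compound 1 by methyl in place of hydrogen on a saturated chain carbon, two bonds along the chain from an aromatic carbon. In this assay compound 2 gives > 10000 nM, again a limit. The step that the two limits leave unreadable from compound 1 to compound 2 therefore has no readable size. Compound 3 `Cc1nnn(Cc2ccc(C(F)(F)F)cc2)c1C(=O)N[C@@H](C)c1ccc(C(=O)O)cc1` carries a methyl group on a core whose difference from the core of compound 1 is not broken down here. In this assay compound 3 gives > 10000 nM, also a limit. All three rest at the limit of > 10000 nM in this assay, at which 3 of the 3 values shown sit.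

Compound 4 `CCc1nnn(Cc2ccc(C(F)(F)F)cc2)c1C(=O)N[C@@H](C)c1ccc(C(=O)O)cc1` differs from compound 3 by methyl in place of hydrogen on a saturated chain carbon bound to an aromatic carbon. This is the same kind of change as that made from compound 1 to compound 2, though the place differs: here it is a saturated chain carbon bound to an aromatic carbon, there a saturated chain carbon two bonds along the chain from an aromatic carbon. The expected step is a step that the limit leaves unreadable from compound 3 to compound 4, resting on the earlier unreadable step that the two limits leave unreadable from compound 1 to compound 2. Among the measured compounds shown here, compound 4 is expected to give 15000 nM in this assay, most likely again only as a limit, because every value so far sits at the limit of > 10000 nM in this assay, at which 3 of the 3 values shown sit.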

Compound 4, half-maximal inhibitory concentration: > 10000 nM
Compound 4: a limit, no number (the forecaster's own chance of this, stated with the estimate: 85%); the middle value is on the limit's open side.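

Compound 3 and compound 4 both rest at a limit of the assay and not at a number, so no size can be read for the change between them: the limit of > 10000 nM in this assay, at which 4 of the 4 values shown sit.

The compounds shown leave open how strongly any of the four inhibits, and whether changing the small alkyl group on either arrangement of the core makes any difference.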